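The compounds below may be only part of what the source reports. "The series", "measured", "known", "first", "only" and "open" are said of these compounds alone.

In an ADME assay on CRL8155 cells (Homo sapiens) for cytotoxicity, read by resazurin assay, with a stated time of 72 h (a higher number here means that more compound is needed for the effect, a lower number that less compound is needed), compound 1 (`O=C(c1ccccc1)c1ccc2nc(NCCC3CCCNC3)[nH]c2c1`) gives > 30000 nM as a limit of the assay, not a number. In this assay compound 2 (`NCCCCNC(=O)Nc1nc2ccc(C(=O)c3ccccc3)cc2[nH]1`) gives > 30000 nM as a limit as well, so it has no number of its own. Going by the values given here, the series so far stands thus: the limit of > 30000 nM in this assay, at which 2 of the 2 values shown sit, in these notes. Among the compounds with values here, the one measured step is a step that the two limits leave unreadable from compound 1 to compound 2 with (4-aminobutyl)carbamoyl in place of 2-(piperidin-3-yl)ethyl on a nitrogen on an aromatic ring. That step gives no size to carry forward.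

Next is compound 3 (`O=C(NCCCCO)Nc1nc2ccc(C(=O)c3ccccc3)cc2[nH]1`), with hydroxy in place of amino on a saturated chain carbon, four bonds along the chain from an amide-type nitrogen in full. Within the data shown here, no measured step bears directly on this change. In this assay no step beyond the scatter is therefore expected, and another limit is the likeliest report. The expected step is a number no higher from compound 2 to compound 3 (the limit leaves the size open) on this estimate. Compound 3 is estimated at 30000 nM with an expected range from 12000 nM to 60000 nM in this assay.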

Compound 3, half-maximal effective concentration: > 30000 nM
Compound 3: no number, only a limit; the forecaster's own chance of this, stated with the estimate: 80%; the middle value sits exactly at the limit.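

No new step can be read in this assay from compound 1 to compound 3 or from compound 2 to compound 3, and the series stands at a single limit: the limit of > 30000 nM in this assay, at which 3 of the 3 values shown sit.

The compounds shown leave open the concentration at which compound 1, compound 2 or compound 3 would reach the half-maximal effect, and whether hydroxy in place of amino shifts it.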